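Naphthyloxyacetyl hydrazones: cytotoxicity on HEL cells

This account rests on a few compounds, and the source may have more. Where it says the series, first, only, none or still open, it means among the compounds named here.

Measured compounds:
- compound 1, `C/C(=N\NC(=O)COc1cccc2ccccc12)c1ccc(C#N)cc1Br`: 12.7 ug/mL
- compound 2, `O=C(COc1cccc2ccccc12)N/N=C/c1ccccc1[N+](=O)[O-]`: 100 ug/mL
- compound 3, `O=C(COc1cccc2ccccc12)N/N=C/c1cccc(O)c1`: 62.7 ug/mL

All three share the naphthyloxyacetyl hydrazone core and differ in the aryl part attached to the carbon with a double bond to nitrogen. In an ADME assay on HEL cells (Homo sapiens) for cytotoxicity (on this read-out higher numbers stand for lower toxicity in this test and lower numbers for higher toxicity in this test), compound 1 gives 12.7 ug/mL, the lowest of the three numbers, so it is the most cytotoxic compound in this set; compound 3 sits nearest to it and compound 2 furthest, both separated from it by more than the scatter. No pair of these compounds differs in a single place, so no single step can be read off directly.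

Compound 4, `C/C(=N\NC(=O)COc1cccc2ccccc12)c1cccc([N+](=O)[O-])c1`, has not yet been measured. It is derived from compound 1 by one change: 3-nitrophenyl in place of 2-bromo-4-cyanophenyl on a carbon with a double bond to nitrogen. The nitro group on the aryl part recurs in compound 2, which gives 100 ug/mL in this assay, the highest number of the three.

On this basis the number for compound 4 is expected to move upward from compound 1, by a step of a 3.1-fold higher number from compound 1 to compound 4 (0.50 log units; beyond the scatter), beyond the scatter but not reaching the top of the set. The estimate for compound 4 is 40 ug/mL, with a range from 15 ug/mL to 100 ug/mL.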

Compound 4, half-maximal cytotoxic concentration: 10.5 ug/mL
Estimate against measurement, compound 4: 3.8-fold (0.58 log units) above, outside the stated range (below it).
By their numbers in this assay, from the lowest: compounds 4 and 1 (each within the scatter of the next); then compounds 3 and 2 (each within the scatter of the next).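

Among these compounds, the first step that can be read at a single place, in this assay, is a 1.2-fold lower number from compound 1 to compound 4 (0.08 log units; within the scatter). Among the compounds shown here, on a carbon with a double bond to nitrogen, 3-nitrophenyl and 2-bromo-4-cyanophenyl are therefore not told apart by this read-out, and in this one pair neither the bromine nor the nitrile of 2-bromo-4-cyanophenyl is needed for a number in this range, although the single swap cannot separate the contributions of the individual substituents. No measured property of these compounds bears on why the two aryl groups read alike.

Steps from compound 1 or compound 4 to compound 2 or compound 3 cannot be read, as each of these pairs differs in more than one place, so the part played by the saturated chain carbon stays unsettled. Also open, as far as these compounds go, is whether an amine or a carboxylic acid on the aryl ring, or a longer chain in place of the saturated chain carbon, would leave the number where compound 1 and compound 4 stand or shift it.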